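The source may hold more compounds than are shown below. What is called first, only, known or untested is meant among the compounds shown, and "the series" means these compounds.

Compound 2 `Cc1cccc(NC[C@@H]2CC3(CC3)CN2C(=O)c2nc(C)sc2-c2ccccc2)n1` has the lowest number of the three measured compounds. In a functional assay on CHO cells for antagonist activity at Orexin/Hypocretin receptor type 1 (Homo sapiens), read by FLIPR and calcium flux (a lower number here means a less potent compound, a higher number a more potent compound, by a factor of ten per unit of this negative logarithm), compound 2 gives 7.3, whereas compound 1 `Cc1cnn(-c2ccc(C)nc2C(=O)N2CC3(CC3)C[C@H]2CNc2ccc(C(F)(F)F)cn2)c1` gives 8.9 and compound 3 `Cc1ccc(-c2nccs2)c(C(=O)N2CC3(CC3)C[C@H]2CNc2ccc(C(F)(F)F)cn2)n1` gives 8.6. Compound 4 `Cc1nc(C(=O)N2CC3(CC3)C[C@H]2CNc2ccc(C(F)(F)F)cn2)c(-c2ccccc2)s1` has not yet been measured. It is derived from compound 2 by one change: 5-(trifluoromethyl)pyridin-2-yl in place of 6-methylpyridin-2-yl on an amine nitrogen. Among the measured compounds shown here, the only step measured between single-change neighbours, a number 0.30 log units lower from compound 1 to compound 3 (within the scatter), concerns a different part of the molecule and so does not bear on this change. Compound 1 and compound 3 both carry the 5-(trifluoromethyl)pyridin-2-yl group that enters here, and both stand well above compound 2, but each also differs from compound 2 in a second place, so the share of that gap that belongs to the amine substituent alone cannot be read off. With that in mind, a gain beyond the scatter is expected from compound 2 to compound 4, a number 0.90 log units higher from compound 2 to compound 4 (beyond the scatter), though with wide uncertainty. Compound 4 is therefore estimated to reach 8.2 in this assay, plausibly anywhere between 7.4 and 8.9.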

Compound 4, negative logarithm of the antagonist equilibrium constant: 8.4
Estimate against measurement, compound 4: 0.20 log units below, and the stated range covers the measured number.
By their numbers in this assay, from the lowest: compound 2; then compounds 4, 3 and 1 (each within the scatter of the next, the first and the last beyond it).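

In this assay, among the compounds shown here, the group on the amine nitrogen matters on its own: a number 1.10 log units higher from compound 2 to compound 4 (beyond the scatter), and this is the first measured step that isolates this group, since compound 1 and compound 3 each differ from compound 2 in a second place as well. The swap of 6-methylpyridin-2-yl for 5-(trifluoromethyl)pyridin-2-yl keeps the six-membered aromatic ring and leaves the counts of hydrogen-bond donors and acceptors unchanged, so this large step comes with a change in the substituent on that ring and in where the name places it. Nothing available here accounts for the size of this gain.

Because the substituent and its place on the ring change together, this single step cannot show which of the two carries the gain, and a plain pyridin-2-yl carrying neither methyl nor trifluoromethyl, or a phenyl in place of the pyridine, would help to separate them. From the compounds shown here alone, it also remains open whether the same swap gives a similar gain with the other groups on the amide carbonyl, as found in compound 1 and compound 3.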